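Fluoro in place of methyl on compound 3

The compounds below may be only part of what the source reports. "The series", "measured", "known", "first", "only" and "open" are said of these compounds alone.

In a functional assay on HepG2 cells (Homo sapiens) for antiproliferative activity, read by MTT assay, with a stated time of 24 h (a higher number here means a weaker inhibitor, a lower number a stronger inhibitor), compound 3 (`Cc1ccc(CSc2nnc(-c3ccc4c(c3)OCCO4)n2-c2ccccc2)cc1`) stands at 56800 nM against compound 1 (`COc1cccc(CSc2nnc(-c3ccc4c(c3)OCCO4)n2-c2ccccc2)c1`) at 35100 nM and compound 2 (`Cc1ccccc1CSc1nnc(-c2ccc3c(c2)OCCO3)n1-c1ccccc1`) at 20500 nM in this small set. Compound 4 (`Fc1ccc(CSc2nnc(-c3ccc4c(c3)OCCO4)n2-c2ccccc2)cc1`) carries fluoro in place of methyl on an aromatic carbon, para to a large group (fluoro in place of methyl on an aromatic carbon). Within the data shown here, no measured compound holds a fluoro group, so the direction of the change is open. Among the measured compounds shown here, the steps that bear on it are a 1.6-fold higher number from compound 1 to compound 3 (0.21 log units; within the scatter) and a 2.8-fold higher number from compound 2 to compound 3 (0.44 log units; beyond the scatter) on the same aromatic ring, and they suggest only a small change. The expected step is a 1.3-fold lower number from compound 3 to compound 4 (0.10 log units; within the scatter) and no move beyond the scatter is expected. For compound 4 the expected value is 45000 nM and the estimated range runs from 20000 nM to 95000 nM in this assay readings.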

Compound 4, half-maximal inhibitory concentration: 1020 nM
Compound 4: middle estimate off by 44-fold (1.64 log units), on the high side, outside the stated range (below it).
By their numbers in this assay, from the lowest: compound 4; then compounds 2, 1 and 3 (each within the scatter of the next, the first and the last beyond it).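

In this assay, among these compounds, the position is far more sensitive to its substituent than the earlier compounds suggested, since the exchange of one heavy atom, methyl for fluoro, gives a 56-fold lower number from compound 3 to compound 4 (1.75 log units; beyond the scatter). The 4-fluorobenzyl group also stands clear of the other two benzyl groups, with a 20-fold lower number from compound 2 to compound 4 (1.30 log units; beyond the scatter) and a 34-fold lower number from compound 1 to compound 4 (1.54 log units; beyond the scatter), which makes compound 4 the strongest inhibitor of the four. Nothing shown here accounts for this gain.

From the compounds shown here alone, whether chloro, a nitrile or an amine in the same place would keep the gain remains open. So does whether fluoro would give a similar step on a different core.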